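The source may report more compounds than this note shows. Statements on the series, on what has been measured and on what is new or still open speak of the compounds shown alone.

Of the compounds shown here, two that share one core have so far been measured in a functional assay on MDA-MB-435S cells (Homo sapiens) for antiproliferative activity, read by MTT assay, with a stated time of 72 h; a lower number here means a stronger inhibitor, a higher number a weaker inhibitor. Compound 1 `CC(C)N(C(=S)SCc1coc2ccccc2c1=O)C(C)C` gives 7900 nM in this assay, and compound 2 `CN1CCN(C(=S)SCc2coc3ccccc3c2=O)CC1` gives 2200 nM. Among the compounds with values here, compound 2 thus holds the lowest of the two numbers, and the only measured step, a 3.6-fold lower number from compound 1 to compound 2 (0.56 log units; beyond the scatter), separates it from compound 1.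

Compound 3 `O=c1c(CSC(=S)N2CCCCC2)coc2ccccc12` is not yet measured. It differs from compound 2 in one place: piperidin-1-yl in place of 4-methylpiperazin-1-yl on a thiocarbonyl carbon. The measured step bears on this change only loosely, since it exchanged diisopropylamino for 4-methylpiperazin-1-yl on the same thiocarbonyl carbon, whereas here one six-membered ring gives way to another. Because a 3.6-fold lower number from compound 1 to compound 2 (0.56 log units; beyond the scatter) was modest, a change at this position is expected to shift the number by a modest amount at most, with no clear direction to be read from the two compounds at hand. Compound 3 is therefore expected to give about 3500 nM in this assay, within a range from 1200 nM to 10000 nM. The expected step, a 1.6-fold higher number from compound 2 to compound 3 (0.20 log units; within the scatter), would be small and may well fall within the scatter.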

Compound 3, half-maximal inhibitory concentration: 470 nM
Compound 3: the middle estimate sits 7.4-fold (0.87 log units) above what was measured, and the stated range ends above it.
By their numbers in this assay, from the lowest: compound 3; then compound 2; then compound 1.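

In this assay, the group on the thiocarbonyl carbon proves more sensitive than the first pair could show: even a swap of one six-membered ring for another, piperidin-1-yl in place of 4-methylpiperazin-1-yl, gives a 4.7-fold lower number from compound 2 to compound 3 (0.67 log units; beyond the scatter) and lies beyond the scatter. The new ring thus differs from the old one by only a single heavy atom count and one hetero atom, yet the number still moves clearly, so a ring at this place does not by itself fix the activity. The full reach of this position among the compounds shown is wider still, with a 17-fold lower number from compound 1 to compound 3 (1.23 log units; beyond the scatter) as piperidin-1-yl replaces diisopropylamino, and compound 3 now has the lowest number of the three, while nothing measured here accounts for these differences.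

The compounds shown leave open whether the ring nitrogen or its methyl in 4-methylpiperazin-1-yl goes with the higher number, a question that piperazine without the methyl, or morpholine with a ring oxygen, would help to answer. Also open, from the compounds shown here alone, is whether a smaller ring such as pyrrolidine, or a larger one such as azepane, would go lower than piperidin-1-yl in this position.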